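The compounds below may be only part of what the source reports. "The series", "measured", "known", "first", "only" and "open" are said of these compounds alone.

Working notes on a small set tested in an assay on membranes from HeLa cells for displacement of a labelled ligand from adenosine receptor A3 (Homo sapiens), read by scintillation counting, with a stated time of 180 min, tested at 1 uM; on this read-out lower numbers stand for less inhibition and higher numbers for more inhibition at the one concentration tested (going by the name of the read-out). Compound 1 `CC1=C(C(=O)NC(C)C)C(c2ccsc2)NC(=O)N1` gives 1% in this assay. For the measured compounds named here, compound 2 `CC1=C(C(=O)SC(C)C)C(c2ccsc2)NC(=O)N1` gives 1% in this assay; the one measured step, no change at the digits printed from compound 1 to compound 2 (within the scatter), is flat. Compound 3 `CC1=C(c2ncc(C)o2)C(c2ccco2)NC(=O)N1`, which carries a 5-methyl-1,3-oxazol-2-yl group and a furan-2-yl group, gives 4% in this assay; this number and those of compound 1 and compound 2 sit within the scatter of one another, so on the numbers shown compound 3 is not separated from either. Compound 1 and compound 3 differ in two places at once, so their values are simply two low numbers side by side.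

Compound 4 `CC1=C(c2ncc(C)o2)C(c2ccsc2)NC(=O)N1` has not been measured. It differs from compound 3 as follows: thiophen-3-yl in place of furan-2-yl on a saturated ring carbon. Going by the values given here, no measured step in this set exchanges one five-membered aromatic ring for another; the only step available, from compound 1 to compound 2, concerns a different place on the shared core and showed nothing beyond the scatter. Among the compounds with values here, with every number so far near the bottom of the scale, the step from compound 3 to compound 4 is expected to be a number 1 percentage points lower from compound 3 to compound 4 (within the scatter), none beyond the scatter. Compound 4 is therefore expected to give about 3% in this assay, in the range 0% to 12%.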

Compound 4, a percentage reported as inhibition, at one concentration (the size of the read-out at that concentration, not a potency): 2%
For compound 4 the middle estimate is 1 percentage points above the measured one; measured number inside the range.
By their numbers in this assay, from the lowest: compounds 1, 2, 4 and 3 (each within the scatter of the next).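

In this assay, for the compounds shown here, thiophen-3-yl in place of furan-2-yl on the saturated ring carbon gives a number 2 percentage points lower from compound 3 to compound 4 (within the scatter), the first measured exchange of one five-membered aromatic ring for another, and this position shows no response to it beyond the scatter. With thiophen-3-yl held constant, the double-bonded ring carbon also shows no response beyond the scatter: 5-methyl-1,3-oxazol-2-yl in place of isopropylcarbamoyl gives a number 1 percentage points higher from compound 1 to compound 4 (within the scatter), and in place of (isopropylsulfanyl)carbonyl gives a number 1 percentage points higher from compound 2 to compound 4 (within the scatter), so at this read-out the ring cannot be told apart from either carbonyl group. Nothing available bears on why these steps are flat.

All of these numbers lie near the bottom of the scale at the single concentration tested, so the flat steps do not show whether either position could affect binding in a series with a higher read-out. From the compounds shown here alone, whether a phenyl ring on the saturated ring carbon, or a carboxylic acid or a longer alkyl chain on the double-bonded ring carbon, would move the number remains open.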